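Swapping Cyclohexyl for Piperidin-1-yl on a Carbonyl

The source may hold more compounds than are shown below. What is called first, only, known or untested is meant among the compounds shown, and "the series" means these compounds.

Measured so far:
Compound 1 `C(#Cc1nc2c(s1)CN(C1CCCCC1)CC2)c1ccccc1`: in an assay on HEK293 cells for positive allosteric modulation of metabotropic glutamate receptor 5 (Homo sapiens), read by FLIPR, with a stated time of 1 h (a lower number here means that less compound is needed, a higher number that more compound is needed for the effect), compound 1 gives only a limit of the assay, > 10000 nM.
Compound 2 `O=C(C1CCCCC1)N1CCc2nc(C#Cc3ccccc3)sc2C1`: in this assay compound 2 gives 167 nM.

For the measured compounds named here, compound 2 holds the only real number in this assay; the other value recorded is a limit. Going by the values given here, the single measured step, an at least 59-fold lower number from compound 1 to compound 2 (1.77 log units; beyond the scatter), was large, and its starting point sits at the limit of > 10000 nM in this assay, at which 1 of the 2 values shown sits, so its full size is not known. Compound 3 `O=C(N1CCCCC1)N1CCc2nc(C#Cc3ccccc3)sc2C1` keeps the carbonyl of compound 2 and changes only the group attached to it: piperidin-1-yl in place of cyclohexyl on a carbonyl carbon. The measured step replaced an amine nitrogen in a ring with a cyclohexylcarbonyl, a carbonyl that compound 3 retains, so that step offers little guidance on this smaller exchange of a ring of carbon only for a ring with one hetero atom. Without a direct precedent, the expected step of a 1.8-fold higher number from compound 2 to compound 3 (0.25 log units; within the scatter) is small, probably within the usual scatter, with a slight lean toward a higher number. Compound 3 is therefore estimated at 300 nM, within a range from 100 nM to 1500 nM.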

Compound 3, half-maximal effective concentration: 75 nM
Compound 3: middle estimate off by 4.0-fold (0.60 log units), on the high side, and the stated range ends above it.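

Piperidin-1-yl in place of cyclohexyl on a carbonyl carbon gives a 2.2-fold lower number from compound 2 to compound 3 (0.35 log units; beyond the scatter) in this assay, so the group on the carbonyl also affects the number, not just the presence of the carbonyl, even though the two rings have the same count of heavy atoms and differ only in one ring carbon exchanged for a nitrogen. Taken together with the carbonyl, the change from cyclohexyl on the amine nitrogen in the ring to (piperidin-1-yl)carbonyl gives an at least 130-fold lower number from compound 1 to compound 3 (2.12 log units; beyond the scatter), the largest step that can be read so far. The true size of that step remains unknown because compound 1 gives a limit and not a number: the limit of > 10000 nM in this assay, at which 1 of the 3 values shown sits.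

One exchange on one carbonyl cannot show whether the lower number comes with the ring nitrogen in general or belongs to piperidin-1-yl alone. Morpholin-4-yl, the smaller pyrrolidin-1-yl ring or an open-chain diethylamino group on the same carbonyl would test this, and a substituent such as fluorine on the phenyl ring at the far end of the shared core is also left open.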